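Swapping a Silicon Group for a Sulfonamide Arm

The source may report more compounds than this note shows. Statements on the series, on what has been measured and on what is new or still open speak of the compounds shown alone.

Compound 2 `C[Si](C)(C)c1cn(C[C@H](O)[C@H]2OC(=O)C(OCc3ccccc3)=C2OCc2ccccc2)nn1`: 22300 nM
Compound 3 `O=C1O[C@H]([C@@H](O)Cn2cc(-c3cc(C(F)(F)F)cc(C(F)(F)F)c3)nn2)C(OCc2ccccc2)=C1OCc1ccccc1`: 35500 nM
Compound 1 `Cc1ccc(-c2cn(C/C=C3\OC(=O)C(OCc4ccccc4)=C3OCc3ccccc3)nn2)cc1`: 7480 nM

All three were tested in a functional assay on HeLa cells (Homo sapiens) for antiproliferative activity, read by MTT assay, with a stated time of 72 h; on this read-out higher numbers stand for weaker inhibition and lower numbers for stronger inhibition. Compound 2 gives the second highest of the three numbers; compound 3 sits within the usual scatter of it, while compound 1 gives a lower number, a gap beyond the scatter. Compound 4 `O=C1O[C@H]([C@@H](O)Cn2cc(CNS(=O)(=O)c3ccc(Cl)cc3)nn2)C(OCc2ccccc2)=C1OCc1ccccc1` has not yet been measured. It differs from compound 2 in one place: a group of 12 heavy atoms (7 carbon, 1 nitrogen, 2 oxygen, 1 sulfur, 1 chlorine; one six-membered aromatic ring of carbon only) in place of a group of 4 heavy atoms (3 carbon, 1 silicon; no ring), on an aromatic carbon. Among the compounds with values here, no pair of measured compounds isolates a change of this kind, so the direction cannot be read from the data. In this assay the change is expected to shift the number only modestly, in either direction, not beyond the scatter: a 1.1-fold lower number from compound 2 to compound 4 (0.05 log units; within the scatter). Compound 4 is therefore estimated at 20000 nM, with a range from 6000 nM to 60000 nM.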

Compound 4, half-maximal inhibitory concentration: 13600 nM
Beside the measured number, compound 4's estimate is 1.5-fold (0.17 log units) above it; the range from low to high includes it.
By their numbers in this assay, from the lowest: compounds 1, 4, 2 and 3 (each within the scatter of the next, the first and the last beyond it).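

In this assay, placing the (((4-chlorophenyl)sulfonyl)amino)methyl group on this aromatic carbon of the five-membered ring gives a 1.6-fold lower number from compound 2 to compound 4 (0.21 log units; within the scatter) for the swap. This position therefore takes a much larger group, one carrying a six-membered aromatic ring and a hydrogen-bond donor, with no difference that stands clear of the scatter. No measurement at hand speaks to the reason for this result.

Going by these compounds, it remains open whether an amine, a carboxylic acid, or the same arm without its chlorine would move the number beyond the scatter at this carbon. Also open, on these data alone, is whether this step would hold on the core of compound 1.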